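Swapping the Indole of Compound 1 for an Acetylphenyl

The source may report more compounds than this note shows. Statements on the series, on what has been measured and on what is new or still open speak of the compounds shown alone.

Compound 1 `COc1cc(-c2ccnc3cc(-c4c[nH]c5ccccc45)nn23)cc(OC)c1OC` holds the lowest number of the three measured in a functional assay on B16-F0 cells (Mus musculus) for inhibition, read by CCK-8 assay, with a stated time of 48 h; on this read-out higher numbers stand for weaker inhibition and lower numbers for stronger inhibition; in that assay compound 1 gives 40 nM. Compound 2 `COc1cc(-c2ccnc3cc(-c4ccccc4)nn23)cc(OC)c1OC` gives 4730 nM, and compound 3 `COc1cc(-c2ccnc3cc(-c4ccc(C(F)(F)F)cc4)nn23)cc(OC)c1OC` gives 1770 nM. Compound 4 `COc1cc(-c2ccnc3cc(-c4ccc(C(C)=O)cc4)nn23)cc(OC)c1OC` has not yet been measured. Its change from compound 1 is this: 4-acetylphenyl in place of 1H-indol-3-yl on an aromatic carbon. Going by the values given here, two measured steps bear directly on it, each replacing the same group with a phenyl: a 120-fold higher number from compound 1 to compound 2 (2.07 log units; beyond the scatter) and a 44-fold higher number from compound 1 to compound 3 (1.65 log units; beyond the scatter). Within that pair, a 2.7-fold lower number from compound 2 to compound 3 (0.43 log units; beyond the scatter) shows that a group on the phenyl shifts the number only modestly. A large rise in this assay is therefore expected for compound 4, a 63-fold higher number from compound 1 to compound 4 (1.80 log units; beyond the scatter). Compound 4 is estimated at 2500 nM, within a range from 800 nM to 8000 nM.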

Compound 4, half-maximal inhibitory concentration: 3930 nM
The estimate for compound 4 lay 1.6-fold (0.20 log units) below the measured number, within the range that was stated.
By their numbers in this assay, from the lowest: compound 1; then compound 3; then compounds 4 and 2 (each within the scatter of the next).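

In this assay, a second substituted phenyl also falls far short of the 1H-indol-3-yl at this position (a 98-fold higher number from compound 1 to compound 4 (1.99 log units; beyond the scatter)). Acetyl and hydrogen on the phenyl lie within the scatter of each other (a 1.2-fold lower number from compound 2 to compound 4 (0.08 log units; within the scatter)), while acetyl and trifluoromethyl are separated by only a modest step (a 2.2-fold higher number from compound 3 to compound 4 (0.35 log units; beyond the scatter)). The compounds come with no evidence that would account for these results. Going by these compounds, it remains open whether an amine or a hydroxyl on the phenyl would narrow the gap to compound 1, and what a methyl on the indole nitrogen would do.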